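Trifluoromethyl for Amino: Expected Permeability of Compound 4

The compounds below may be only part of what the source reports. "The series", "measured", "known", "first", "only" and "open" are said of these compounds alone.

Measured compounds:
compound 1 `Cc1cc(NC(=O)Nc2ccc(N)cc2)c2ccccc2n1` — 530 10^-6 cm/s
compound 2 `Cc1cc(NC(=O)Nc2ccccc2F)c2ccccc2n1` — 817 10^-6 cm/s
compound 3 `Cc1cc(NC(=O)Nc2ccccc2N)c2ccccc2n1` — 300 10^-6 cm/s

In an ADME assay for permeability, using PAMPA, at pH 7.4 (a lower number here means that the compound crosses the layer more slowly, a higher number that the compound crosses the layer faster), compound 1 gives 530 10^-6 cm/s, which places it in the middle of the three numbers, though compound 2 with 817 10^-6 cm/s and compound 3 with 300 10^-6 cm/s both lie within the scatter of it (a 1.5-fold higher number from compound 1 to compound 2 (0.19 log units; within the scatter); a 1.8-fold lower number from compound 1 to compound 3 (0.25 log units; within the scatter)). Compound 4 `Cc1cc(NC(=O)Nc2ccc(C(F)(F)F)cc2)c2ccccc2n1` differs from compound 1 by trifluoromethyl in place of amino on an aromatic carbon. For the measured compounds named here, the one step that bears on this is a 2.7-fold lower number from compound 2 to compound 3 (0.44 log units; beyond the scatter), modest but beyond the scatter; read in reverse, replacing an amino by a fluorine-bearing group went with a higher number. A modestly higher number is therefore expected for compound 4, a 1.7-fold higher number from compound 1 to compound 4 (0.23 log units; within the scatter). Compound 4 is estimated at 900 10^-6 cm/s, with a range from 480 10^-6 cm/s to 1600 10^-6 cm/s.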

Compound 4, apparent permeability: 2 10^-6 cm/s
The estimate for compound 4 lay 450-fold (2.65 log units) above the measured number, outside the stated range (below it).
By their numbers in this assay, from the lowest: compound 4; then compounds 3, 1 and 2 (each within the scatter of the next, the first and the last beyond it).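

In this assay, for the compounds shown here, trifluoromethyl in place of amino on this aromatic carbon, para to a large group, gives a 270-fold lower number from compound 1 to compound 4 (2.42 log units; beyond the scatter), whereas the only earlier step beyond the scatter was a 2.7-fold lower number from compound 2 to compound 3 (0.44 log units; beyond the scatter), which is far smaller. Going by these compounds alone, this place on the ring can therefore carry a much steeper change than the earlier compounds showed. Nothing measured here accounts for that fall.

The compounds shown leave open whether the fall follows the trifluoromethyl entering or the amino leaving, and how a methoxy or chloro group on the same carbon would read.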